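The source may hold more compounds than are shown below. What is called first, only, known or untested is meant among the compounds shown, and "the series" means these compounds.

Of the compounds shown here, two have numbers so far in an in vitro functional assay on HEK ts201 cells for antagonist activity at Neuronal acetylcholine receptor; alpha4/beta2 (Homo sapiens), read by fluorescence and calcium flux; a lower number here means a stronger inhibitor, a higher number a weaker inhibitor. Compound 1, with the structure `O=C(CCC1CCCNC1)c1ccccc1-c1ccccc1`, gives 9120 nM. Compound 2, with the structure `CC1CC(=O)N(c2ccccc2C(=O)OCC2CCCN(CCCCCOc3ccc(Cl)c(Cl)c3)C2)C1=O`, gives 17400 nM, which lies within the usual scatter of the number for compound 1, so the two cannot be told apart. Compound 3, with the structure `COc1ccc(OCCCCCN2CCCC(COC(=O)c3ccccc3N3C(=O)CC(C)C3=O)C2)cc1`, has not yet been measured; it differs from compound 2 in one place: 4-methoxyphenyl in place of 3,4-dichlorophenyl on an oxygen on a saturated carbon. Within the data shown here, no measured pair shows this change, so the step from compound 2 to compound 3 in this assay is expected to be small, most likely none beyond the scatter, as a 1.1-fold higher number from compound 2 to compound 3 (0.06 log units; within the scatter). Compound 3 is therefore estimated at 20000 nM, within a range from 8000 nM to 50000 nM.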

Compound 3, half-maximal inhibitory concentration: 14500 nM
The estimate for compound 3 lay 1.4-fold (0.14 log units) above the measured number, and the stated range covers the measured number.
By their numbers in this assay, from the lowest: compounds 1, 3 and 2 (each within the scatter of the next).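

In this assay, putting 4-methoxyphenyl in place of 3,4-dichlorophenyl on the oxygen gives a 1.2-fold lower number from compound 2 to compound 3 (0.08 log units; within the scatter), so the two groups cannot be told apart at this position. Among these compounds, this is the first comparison of compounds that differ in one place, and it shows that this exchange of ring groups does not move the number beyond the scatter. No measurement at hand offers an explanation for this result. On these data alone, it remains open whether an amine or a carboxylic acid on this aromatic ring would shift the number beyond the scatter.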